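The source may hold more compounds than are shown below. What is called first, only, known or untested is meant among the compounds shown, and "the series" means these compounds.

Working notes on the series. a functional assay on HeLa cells (Homo sapiens) for antiproliferative activity, read by MTT assay, with a stated time of 72 h (on this read-out higher numbers stand for weaker inhibition and lower numbers for stronger inhibition), has so far been run on three compounds. Compound 1 `COc1cc(-n2ncnc2-c2ccc(OC(C)C)cc2)cc(OC)c1OC` gives 600 nM in this assay. Compound 3 `COc1ccc(-n2ncnc2-c2cc(OC)c(OC)c(OC)c2)cc1` reaches only the limit of this assay, > 10000 nM. Compound 2 `COc1ccccc1-c1ncnn1-c1cc(OC)c(OC)c(OC)c1` likewise returns only the limit, > 10000 nM, so no number is known for it; of the three values shown, two sit at the limit, (the limit of > 10000 nM in this assay, at which 2 of the 3 values shown sit), and compound 1 alone gives a measured figure.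

Compound 4 `COc1cc(-n2ncnc2-c2ccc(F)cc2)cc(OC)c1OC` has not yet been measured in this assay. It differs from compound 2 in one place: 4-fluorophenyl in place of 2-methoxyphenyl on an aromatic carbon. The new group sits on an aromatic carbon of the five-membered aromatic ring with three nitrogens, between two ring nitrogen atoms, next to the ring atom that bears a large group, two ring bonds from the ring nitrogen.

Because compound 2 sits at the limit of this assay, > 10000 nM, only a downward step is visible at all, and its size is open. The expected step from compound 2 to compound 4 in this assay is an at least 2.5-fold lower number from compound 2 to compound 4 (0.39 log units; beyond the scatter); compound 4 is estimated at 4000 nM, in the range 700 nM to 20000 nM, with a fair chance that only the limit is returned again.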

Compound 4, half-maximal inhibitory concentration: > 10000 nM
Compound 4 gave a limit, no number; the forecaster's own chance of this, stated with the estimate: 40%; middle value at least 2.5-fold (0.39 log units) away from the limit.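

In this assay compound 4 returns only a limit, > 10000 nM, and no number. Fluoro in place of isopropoxy on an aromatic carbon gives an at least 16-fold higher number from compound 1 to compound 4 (1.22 log units; beyond the scatter), the first step in the series that can be sized, so the measured activity of compound 1 does not survive this single change. The step between compound 2 and compound 4 cannot be read, and the series still rests on one measured figure: the limit of > 10000 nM in this assay, at which 3 of the 4 values shown sit.

The compounds shown leave open whether isopropoxy itself is required, or whether an ethoxy, a longer alkoxy chain or an amine in its place would also return a number. They also leave open how far compound 2 and compound 4 lie beyond the limit, so the 2-methoxyphenyl and 4-fluorophenyl groups cannot be ranked.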